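The compounds below may be only part of what the source reports. "The series", "measured", "known", "first", "only" and "open" are said of these compounds alone.

In an assay on CHO cells for displacement of a labelled ligand from prostaglandin D2 receptor 2 (Homo sapiens), read by scintillation counting (a lower number here means a stronger inhibitor, a higher number a weaker inhibitor), compound 3 `CCCS(=O)(=O)c1ccc(C)c(C#Cc2cc(Cl)ccc2OC(CC(C)C)C(=O)O)c1` gives 515 nM, the highest number among the three measured compounds. Compound 2 `CCCS(=O)(=O)c1ccc(C)c(C#Cc2cc(Cl)ccc2OC(C)C(=O)O)c1` gives 1.2 nM in this assay, and compound 1 `COC1c2ccc(C#Cc3cc(Cl)ccc3OCC(=O)O)cc2S(=O)(=O)C1(C)C` gives 21 nM. Compound 4 `CCCS(=O)(=O)c1ccc(C)c(C#Cc2cc(Cl)ccc2OC(CC)C(=O)O)c1` differs from compound 3 by methyl in place of isopropyl on a saturated chain carbon, two bonds along the chain from a carbonyl carbon and an oxygen on an aromatic ring. For the measured compounds named here, one measured step bears on this change: a 430-fold higher number from compound 2 to compound 3 (2.63 log units; beyond the scatter). The present change takes away much of what that step had added at the same place on the chain, so a large fall in this assay is expected, though perhaps not all the way back to the number of compound 2. Compound 4 is therefore expected to show a 52-fold lower number from compound 3 to compound 4 (1.71 log units; beyond the scatter). Compound 4 is estimated at 10 nM in this assay, with a likely range from 2 nM to 60 nM.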

Compound 4, inhibition constant: 30 nM
The estimate for compound 4 lay 3.0-fold (0.48 log units) below the measured number; the range from low to high includes it.
By their numbers in this assay, from the lowest: compound 2; then compounds 1 and 4 (each within the scatter of the next); then compound 3.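

In this assay, the step of a 17-fold lower number from compound 3 to compound 4 (1.23 log units; beyond the scatter) shows that ethyl in place of isobutyl at this chain carbon recovers much of the lost strength, but not all of it. The step of a 25-fold higher number from compound 2 to compound 4 (1.40 log units; beyond the scatter) shows that a single added methyl on the chain already raises the number substantially, so the rise is not confined to isobutyl. Across compound 2, compound 4 and compound 3, the number climbs at each step as this chain grows.

From the compounds shown here alone, whether a straight propyl chain or a cyclopropyl ring would follow the same rise stays open. No measurement shown here accounts for these steps.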